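Working notes: three measured analogues and a fourth to test

This account rests on a few compounds, and the source may have more. Where it says the series, first, only, none or still open, it means among the compounds named here.

Measured so far:
compound 1, `O=C1/C(=C/c2ccccc2)CCc2ccc(O)cc21`, gives 710 nM in a functional assay on RAW264.7 cells (Mus musculus) for inhibition; on this read-out higher numbers stand for weaker inhibition and lower numbers for stronger inhibition.
compound 2, `O=C1/C(=C/c2ccccc2F)CCc2ccc(O)cc21`, gives 1350 nM in this assay.
compound 3, `O=C1/C(=C/c2ccccc2C(F)(F)F)CCc2ccc(O)cc21`, gives 1020 nM in this assay.

Compound 3 stands second highest of the three numbers. Its nearest neighbour is compound 2, with a 1.3-fold lower number from compound 2 to compound 3 (0.12 log units; within the scatter); the furthest is compound 1, with a 1.4-fold higher number from compound 1 to compound 3 (0.16 log units; within the scatter). The remaining step, a 1.9-fold higher number from compound 1 to compound 2 (0.28 log units; within the scatter), is likewise within the scatter, so the three compounds cannot be ordered on these numbers.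

The next compound, compound 4, `O=C1/C(=C/c2ccccc2OC(F)(F)F)CCc2ccc(O)cc21`, differs from compound 3 in one place: trifluoromethoxy in place of trifluoromethyl on an aromatic carbon.

All three measured steps bear on this change, since each exchanges the group on the same aromatic carbon, and none of them moved the number beyond the scatter. No step beyond the scatter is therefore expected in this assay for this exchange either, in no particular direction. Compound 4 is expected to give about 1000 nM, with a range from 400 nM to 2500 nM, which amounts to an expected step of a 1.0-fold lower number from compound 3 to compound 4 (0.01 log units; within the scatter).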

Compound 4, half-maximal inhibitory concentration: 420 nM
Compound 4: the middle estimate sits 2.4-fold (0.38 log units) above what was measured; measured number inside the range.
By their numbers in this assay, from the lowest: compounds 4, 1, 3 and 2 (each within the scatter of the next, the first and the last beyond it).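

In this assay, among the compounds shown here, this aromatic carbon now shows steps beyond the scatter for the first time: trifluoromethoxy in place of trifluoromethyl gives a 2.4-fold lower number from compound 3 to compound 4 (0.39 log units; beyond the scatter) and trifluoromethoxy in place of fluoro gives a 3.2-fold lower number from compound 2 to compound 4 (0.51 log units; beyond the scatter) on the same carbon. So this position does respond to the exchange of one group for another, and the added oxygen of trifluoromethoxy separates compound 4 from compound 3. The comparison with hydrogen does not extend this, since trifluoromethoxy in place of hydrogen gives a 1.7-fold lower number from compound 1 to compound 4 (0.23 log units; within the scatter) and compound 4 is therefore not separated from compound 1.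

Still open, as far as these compounds go, is whether the oxygen alone carries the step, which methoxy on the same aromatic carbon would address, and how an amine or a carboxylic acid there would compare. Nothing shown gives a reason for the step.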